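This account rests on a few compounds, and the source may have more. Where it says the series, first, only, none or still open, it means among the compounds named here.

Compound 1 `CNc1nc(NCc2ccc(C(=O)Nc3ccc(F)cc3)cc2)c2ccccc2n1` gives the highest number of the three in a functional assay on SW480 cells (Homo sapiens) for inhibition, read by luminescence and resazurin assay, with a stated time of 3 days (on this read-out higher numbers stand for weaker inhibition and lower numbers for stronger inhibition), 4100 nM. Compound 2 `CCCNc1nc(NCc2ccc(C(=O)Nc3ccc(F)cc3)cc2)c2ccccc2n1` gives 1600 nM and compound 3 `CC1CN(c2nc(NCc3ccc(C(=O)Nc4ccc(F)cc4)cc3)c3ccccc3n2)CCN1` gives 3200 nM. The step of a 2.6-fold lower number from compound 1 to compound 2 (0.41 log units; beyond the scatter) is beyond the scatter, whereas a 1.3-fold lower number from compound 1 to compound 3 (0.11 log units; within the scatter) and a 2.0-fold higher number from compound 2 to compound 3 (0.30 log units; within the scatter) stay within it. All three measured steps alter the group on the shared core; none touches the six-membered aromatic ring of carbon only where compound 4 differs. Going by the values given here, compound 4 `CNc1nc(NCc2ccc(NC(=O)c3ccncc3)cc2)c2ccccc2n1` differs from compound 1 by ((pyridin-4-yl)carbonyl)amino in place of (4-fluorophenyl)carbamoyl on an aromatic carbon, a change with no measured counterpart; the measured steps give no direction for it. For compound 4 the number in this assay is expected near that of compound 1, a 1.5-fold higher number from compound 1 to compound 4 (0.17 log units; within the scatter), with a wide range. The estimate for compound 4 is 6000 nM, between 1500 nM and 25000 nM.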

Compound 4, half-maximal inhibitory concentration: > 20000 nM
Compound 4 was reported as a limit; the forecaster's own chance of this, stated with the estimate: 10%; middle value at least 3.3-fold (0.52 log units) away from the limit.
By their numbers in this assay, from the lowest: compounds 2, 3 and 1 (each within the scatter of the next, the first and the last beyond it). At a limit, above all of these: compound 4.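

In this assay, going by these compounds alone, ((pyridin-4-yl)carbonyl)amino in place of (4-fluorophenyl)carbamoyl gives the first step at this place, and it lies beyond the scatter: an at least 4.8-fold higher number from compound 1 to compound 4 (0.68 log units; beyond the scatter). Compound 4 stands at > 20000 nM, which is a limit and not a number. The change replaces the ring of carbon only with a ring holding a hetero atom and also turns carbamoyl into carbonylamino, so this single step covers both.

The compounds shown do not separate the two changes. A (pyridin-4-yl)carbamoyl group or a ((4-fluorophenyl)carbonyl)amino group on the same core would bear on that question.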